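This account rests on a few compounds, and the source may have more. Where it says the series, first, only, none or still open, it means among the compounds named here.

In a functional assay on MDA-MB-231 cells (Homo sapiens) for antiproliferative activity, read by MTT assay, with a stated time of 24 h (on this read-out higher numbers stand for weaker inhibition and lower numbers for stronger inhibition), three compounds sharing one core have been measured. Compound 1 `O=C(NNc1ccccc1F)c1ccc(NS(=O)(=O)c2cnc(O)nc2O)cc1` gives > 20000 nM, which is a limit and not a number. Compound 2 `Cc1ccccc1C(=O)NNC(=O)c1ccc(NS(=O)(=O)c2cnc(O)nc2O)cc1` gives 7040 nM. Compound 3 `Cc1ccc(C(=O)NNC(=O)c2ccc(NS(=O)(=O)c3cnc(O)nc3O)cc2)cc1` gives > 20000 nM, again only a limit, so compound 3 stands at the limit of > 20000 nM in this assay, at which 2 of the 3 values shown sit.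

Compound 4 `O=C(NNC(=O)c1ccccc1Cl)c1ccc(NS(=O)(=O)c2cnc(O)nc2O)cc1` is the next case: 2-chlorophenyl replaces 4-methylphenyl on a carbonyl carbon (2-chlorophenyl in place of 4-methylphenyl on a carbonyl carbon). The closest measured change is an at least 2.8-fold higher number from compound 2 to compound 3 (0.45 log units; beyond the scatter), where 4-methylphenyl replaced 2-methylphenyl at that same place. Another measured change, an at least 2.8-fold lower number from compound 1 to compound 2 (0.45 log units; beyond the scatter), also reaches the one measured number, while a step that the two limits leave unreadable from compound 1 to compound 3 gives no usable size.

Compound 4 has 2-chlorophenyl where compound 2 has 2-methylphenyl, so it is expected to resemble compound 2 more than compound 3, although this rests on a single pair and another limit remains possible. The expected change is an at least 2.0-fold lower number from compound 3 to compound 4 (0.30 log units; that floor lies within the scatter), towards stronger inhibition. For compound 4 the estimated value is 10000 nM, with an expected range of 4000 nM to 25000 nM.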

Compound 4, half-maximal inhibitory concentration: 13900 nM
The estimate for compound 4 lay 1.4-fold (0.14 log units) below the measured number; the range from low to high includes it.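

With compound 4, this assay gives a second true number for a group on this carbonyl carbon, where until now only compound 2 had one. Chloro in place of methyl on an aromatic carbon gives a 2.0-fold higher number from compound 2 to compound 4 (0.30 log units; within the scatter), so at this position the two groups cannot be told apart on this read-out. The other two steps are only floors, an at least 1.4-fold lower number from compound 3 to compound 4 (0.15 log units; that floor lies within the scatter) and an at least 1.4-fold lower number from compound 1 to compound 4 (0.15 log units; that floor lies within the scatter), and each starts from a value that is a limit of the assay and not a number: the limit of > 20000 nM in this assay, at which 2 of the 4 values shown sit.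

Going by these compounds, it remains open whether 4-chlorophenyl on this carbonyl carbon would give a number, as 2-chlorophenyl does, or only a limit, as 4-methylphenyl does. Also open, on these data alone, is how a plain phenyl or a 2-methoxyphenyl would read at the same place.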